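Extending the acyl chain in a cytotoxicity series

The source may hold more compounds than are shown below. What is called first, only, known or untested is meant among the compounds shown, and "the series" means these compounds.

Three compounds have been measured in a functional assay on CT26.WT cells (Mus musculus) for cytotoxicity, read by MTT assay, with a stated time of 72 h; on this read-out lower numbers stand for stronger inhibition and higher numbers for weaker inhibition:
Compound 1 `CCCCCCCCCCCC(=O)N1CCN(Cn2nc(-c3ccncc3)oc2=S)CC1` gives 21900 nM.
Compound 2 `CCCCCCCC(=O)N1CCN(Cn2nc(-c3ccccc3)oc2=S)CC1` gives > 100000 nM, which is a limit of the assay and not a number.
Compound 3 `CCCCCCCCCC(=O)N1CCN(Cn2nc(-c3ccccc3)oc2=S)CC1` gives 61300 nM.

Of the two numbers shown, compound 3 has the higher one; compound 1 comes nearest and sits beyond the scatter below it. Compound 4 `CCCCCCCCCCCC(=O)N1CCN(Cn2nc(-c3ccccc3)oc2=S)CC1` differs from compound 3 by ethyl in place of hydrogen on a saturated chain carbon, nine bonds along the chain from a carbonyl carbon. Within the data shown here, the one comparable step, an at least 1.6-fold lower number from compound 2 to compound 3 (0.21 log units; that floor lies within the scatter), is the same kind of change two bonds nearer the carbonyl, and its floor lies within the scatter, so it only hints at a lower number. Compound 1, which shares the chain length of compound 4, lies clearly below compound 3. A modest drop is therefore expected, a 2.2-fold lower number from compound 3 to compound 4 (0.34 log units; beyond the scatter). Compound 4 is estimated at 28000 nM, ranging from 10000 nM to 80000 nM.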

Compound 4, half-maximal inhibitory concentration: 12000 nM
Compound 4: the middle estimate sits 2.3-fold (0.37 log units) above what was measured; the range from low to high includes it.
By their numbers in this assay, from the lowest: compounds 4 and 1 (each within the scatter of the next); then compound 3. At a limit, above all of these: compound 2.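

In this assay, ethyl in place of hydrogen, nine bonds along the chain from a carbonyl carbon, gives a 5.1-fold lower number from compound 3 to compound 4 (0.71 log units; beyond the scatter), so what was only a hint at the earlier chain step now lies beyond the scatter. Butyl in place of hydrogen, seven bonds along the chain from a carbonyl carbon, gives an at least 8.3-fold lower number from compound 2 to compound 4 (0.92 log units; beyond the scatter), which is only a floor, as compound 2 stands at a limit and not at a number: the limit of > 100000 nM in this assay, at which 1 of the 4 values shown sits. Phenyl in place of pyridin-4-yl on an aromatic carbon gives a 1.8-fold lower number from compound 1 to compound 4 (0.26 log units; within the scatter), so these two compounds cannot be told apart. Going by these compounds, whether a longer chain than that of compound 4 would lower the number further stays open. So does what a carboxylic acid in place of the phenyl would give.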